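Aryl exchange on the shared core: permeability notes

The source may hold more compounds than are shown below. What is called first, only, known or untested is meant among the compounds shown, and "the series" means these compounds.

Among the compounds with values here, compound 1 `Cc1oc(-c2ccc(Cl)c(Cl)c2)nc1CN1CCC(C(=O)NCCCN2C[C@H](C)C[C@H](C)C2)CC1` gives 522 10^-6 cm/s in a physicochemical assay for permeability, using PAMPA (a higher number here means that the compound crosses the layer faster, a lower number that the compound crosses the layer more slowly), and compound 2 `Cc1ccccc1-c1nc(CN2CCC(C(=O)NCCN3C[C@H](C)C[C@H](C)C3)CC2)c(C)o1` gives 712 10^-6 cm/s in this assay; the two values lie within the scatter of each other, so compound 1 stands level with the only other measured compound. Compound 3 `Cc1cc(C)cc(-c2nc(CN3CCC(C(=O)NCCCN4C[C@H](C)C[C@H](C)C4)CC3)c(C)o2)c1` remains to be measured. It differs from compound 1 by 3,5-dimethylphenyl in place of 3,4-dichlorophenyl on an aromatic carbon. Within the data shown here, no measured pair informs this change, and the step of a 1.1-fold higher number from compound 1 to compound 3 (0.02 log units; within the scatter) is expected to stay within the scatter, with no clear direction. Compound 3 is estimated at 550 10^-6 cm/s, in the range 300 10^-6 cm/s to 950 10^-6 cm/s.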

Compound 3, apparent permeability: 864 10^-6 cm/s
The estimate for compound 3 lay 1.6-fold (0.20 log units) below the measured number, within the range that was stated.
By their numbers in this assay, from the lowest: compounds 1, 2 and 3 (each within the scatter of the next).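

In this assay, within the data shown here, 3,5-dimethylphenyl in place of 3,4-dichlorophenyl gives a 1.7-fold higher number from compound 1 to compound 3 (0.22 log units; within the scatter), the first step that can be read at this aromatic carbon of the shared core. Within this one pair, two chlorine atoms give way to carbon at an equal heavy-atom count, with the step staying within the scatter.

Going by these compounds, whether a pyridyl ring, or an amine or carboxylic acid on the phenyl ring, would also stay within the scatter here remains open. No measurement shown explains the step.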